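The source may report more compounds than this note shows. Statements on the series, on what has been measured and on what is new or still open speak of the compounds shown alone.

Series notes. Among the compounds with values here, compound 1 `C[C@@H]1CCC[C@H](C)N1Cc1cc2c(N)nc(-c3ccc(C4CC4)o3)nc2s1` carries a 5-cyclopropylfuran-2-yl group on the shared core; in an assay on CHO-K1 cells for antagonist activity at adenosine receptor A1 (Homo sapiens), read by a beta-galactosidase reporter, with stated times of 15 min and 6 h (a higher number here means a weaker inhibitor, a lower number a stronger inhibitor), compound 1 gives 330 nM, the lowest of the three numbers measured so far. Compound 2 `Nc1nc(-c2ccc(Cl)o2)nc2sc(CN3CC=CC3)cc12` gives 780 nM in this assay, and compound 3 `Nc1nc(-c2ncco2)nc2sc(CN3CC=CC3)cc12` gives 3890 nM. Within the data shown here, the one measured step at the same point of the core, a 5.0-fold higher number from compound 2 to compound 3 (0.70 log units; beyond the scatter), shows that exchanging the aromatic group there moves the number beyond the scatter. Compound 4 `C[C@@H]1CCC[C@H](C)N1Cc1cc2c(N)nc(-c3cccc(C#N)c3)nc2s1` is not yet measured; it differs from compound 1 in that (3-cyanophenyl in place of 5-cyclopropylfuran-2-yl on an aromatic carbon). Among the measured compounds shown here, that change swaps a five-membered aromatic ring with one hetero atom for a six-membered aromatic ring of carbon only while keeping one substituent on it, so it sits at the same position as the measured step between compound 2 and compound 3 but is of a different kind, and no measured step matches it directly. For the measured compounds named here, the only guidance is that compound 2 and compound 3 show a modest loss on changing this ring, and a comparable though somewhat smaller step upward in this assay is therefore expected for compound 4, namely a 2.4-fold higher number from compound 1 to compound 4 (0.38 log units; beyond the scatter). Compound 4 is estimated at 800 nM, with a range from 250 nM to 2500 nM.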

Compound 4, inhibition constant: 460 nM
For compound 4 the middle estimate is 1.7-fold (0.24 log units) above the measured one, and the stated range covers the measured number.
By their numbers in this assay, from the lowest: compounds 1, 4 and 2 (each within the scatter of the next, the first and the last beyond it); then compound 3.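

In this assay, exchanging 5-cyclopropylfuran-2-yl for 3-cyanophenyl on this aromatic carbon gives a 1.4-fold higher number from compound 1 to compound 4 (0.14 log units; within the scatter), so with the side chain of compound 1 the two groups cannot be told apart, although one is a five-membered aromatic ring with one hetero atom plus a three-membered ring, and the other is a six-membered aromatic ring of carbon only with a nitrile. Exchanges of the aromatic group at this position therefore do not always move the number beyond the scatter, as the only earlier step, a 5.0-fold higher number from compound 2 to compound 3 (0.70 log units; beyond the scatter), might have suggested, though that step involves different groups and a different side chain. Nothing on hand accounts for either step in structural terms.

The compounds shown do not separate the six-membered ring from its substituent, and a plain phenyl group, or a phenyl carrying a carboxylic acid or an amine in place of the nitrile, would address that. Going by these compounds, it also remains open whether 3-cyanophenyl gives a similar number on the side chain of compound 2, where the aromatic group has so far been exchanged with a step beyond the scatter.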